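Chloro in Place of Fluoro on the Benzyl Arm

The compounds below may be only part of what the source reports. "The series", "measured", "known", "first", "only" and "open" are said of these compounds alone.

Three compounds built on a shared core differ only in the aryl group carried on a saturated chain carbon bound to an aromatic nitrogen. Compound 1 `Cc1ccc(Cn2cc(COc3ccc4c(=O)ccoc4c3)nn2)cc1` bears a 4-methylphenyl group. In a functional assay on MDA-MB-231 cells (Homo sapiens) for cytotoxicity, read by MTT assay, with a stated time of 48 h (on this read-out lower numbers stand for stronger inhibition and higher numbers for weaker inhibition), compound 1 reaches only the limit of the assay, > 100000 nM. Compound 2 `O=c1ccoc2cc(OCc3cn(Cc4ccc(Cl)cc4)nn3)ccc12` carries a 4-chlorophenyl group. In this assay compound 2 likewise gives a limit, > 100000 nM. Compound 3 `O=c1ccoc2cc(OCc3cn(Cc4cccc(F)c4)nn3)ccc12` carries a 3-fluorophenyl group. In this assay compound 3 also gives a limit, > 100000 nM. The steps between them, a step that the two limits leave unreadable from compound 1 to compound 2, a step that the two limits leave unreadable from compound 1 to compound 3 and a step that the two limits leave unreadable from compound 2 to compound 3, cannot be sized, a situation summed up by the limit of > 100000 nM in this assay, at which 3 of the 3 values shown sit. Compound 3 therefore stands, as far as the numbers show, level with the other two at the limit.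

Compound 4 `O=c1ccoc2cc(OCc3cn(Cc4cccc(Cl)c4)nn3)ccc12` differs from compound 3 in one place: chloro in place of fluoro on an aromatic carbon. No measured step sizes an exchange of this kind, and the steps already named were all unreadable. Because compound 3 reaches only the limit > 100000 nM, compound 4 is expected to stay near it as well, at an estimated 150000 nM. That expectation amounts to a step that the limit leaves unreadable from compound 3 to compound 4 in this assay, with the estimate for compound 4 spanning 50000 nM to 500000 nM.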

Compound 4, half-maximal inhibitory concentration: > 100000 nM
Compound 4 gave a limit, no number (the forecaster's own chance of this, stated with the estimate: 85%); the middle value is on the limit's open side.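

In this assay compound 4 gives > 100000 nM, a limit and not a number. Its steps from compound 1, compound 2 and compound 3 therefore cannot be read, and all four compounds stand together: the limit of > 100000 nM in this assay, at which 4 of the 4 values shown sit. The compounds shown leave open whether any of these exchanges on the benzyl arm changes the cytotoxicity at all.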